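The compounds below may be only part of what the source reports. "The series", "measured", "known", "first", "only" and "open" are said of these compounds alone.

Measured compounds in the series:

Compound 1, `CCn1c(C(=O)NCCC(=O)OC)ccc1C(CC)(CC)c1ccc(OCS(=O)(=O)c2ccccc2)c(C)c1`. In a functional assay on MCF7 cells (Homo sapiens) for antiproliferative activity, read by MTT assay, with a stated time of 24 h (on this read-out higher numbers stand for weaker inhibition and lower numbers for stronger inhibition), compound 1 gives > 50000 nM, which is a limit of the assay and not a number.
Compound 2, `CCn1c(C(=O)NCCN)ccc1C(CC)(CC)c1ccc(OCS(=O)(=O)c2ccccc2)c(C)c1`. Compound 2 gives 6470 nM in this assay.
Compound 3, `CCn1c(C(=O)N[C@@H](CO)CCCO)ccc1C(CC)(CC)c1ccc(OCS(=O)(=O)c2ccccc2)c(C)c1`. Compound 3 gives 29600 nM in this assay.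

Compound 2 stands lowest of the two numbers shown, with compound 3 nearest: a 4.6-fold higher number from compound 2 to compound 3 (0.66 log units; beyond the scatter). Compound 1 sits at the limit (the limit of > 50000 nM in this assay, at which 1 of the 3 values shown sits). Among the measured compounds shown here, the one step from a chain ending in an ester to one ending in an amine reads an at least 7.7-fold lower number from compound 1 to compound 2 (0.88 log units; beyond the scatter).

The unmeasured compound 4, `CCn1c(C(=O)N[C@@H](CCC(=O)O)C(=O)O)ccc1C(CC)(CC)c1ccc(OCS(=O)(=O)c2ccccc2)c(C)c1`, differs from compound 2 in one place: 1,3-dicarboxypropyl in place of 2-aminoethyl on an amide-type nitrogen.

For the measured compounds named here, two measured steps bear on this change. From compound 2 to compound 3, a larger neutral chain on the amide-type nitrogen in place of 2-aminoethyl gave a modest rise beyond the scatter. Going by the values given here, from compound 1 to compound 2, removing the ester in favour of the amine gave the one clearly lower number. Compound 4 carries two carboxy groups and no amine, so the expectation is a step upward of the kind seen for compound 3, possibly reaching the limit.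

Compound 4 is therefore expected at 30000 nM, with a range of 10000 nM to 100000 nM, which means an estimated step of a 4.6-fold higher number from compound 2 to compound 4 (0.67 log units; beyond the scatter).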

Compound 4, half-maximal inhibitory concentration: > 50000 nM
Compound 4 was reported as a limit; the forecaster's own chance of this, stated with the estimate: 35%; middle value at least 1.6-fold (0.22 log units) away from the limit.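

On the amide-type nitrogen, 1,3-dicarboxypropyl in place of 2-aminoethyl gives an at least 7.7-fold higher number from compound 2 to compound 4 (0.88 log units; beyond the scatter) in this assay and so adds a third chain without an amine to the series, with compound 2 still holding the lowest number shown. The step to the chain with two carboxy groups from the chain with two hydroxyl groups reads an at least 1.6-fold higher number from compound 3 to compound 4 (0.22 log units; that floor lies within the scatter) and with that floor no order between these two chains can be stated. Compound 4 gives > 50000 nM as a limit of the assay and not a number, and the step between compound 1 and compound 4 cannot be read, leaving both compounds together at one limit: the limit of > 50000 nM in this assay, at which 2 of the 4 values shown sit.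

Going by these compounds, whether a single carboxylic acid, as a 2-carboxyethyl chain, would read differently from the methyl ester of compound 1 stays open. On these data alone, it is also open whether a longer chain such as 3-aminopropyl, or a dimethylamine at the chain end, would keep or lower the number of compound 2 in this assay.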